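From Ethoxy to Carboxy: Expecting a Weaker Compound 3

This account rests on a few compounds, and the source may have more. Where it says the series, first, only, none or still open, it means among the compounds named here.

Compound 2 `CCOc1cccc(N/N=C2\CCC(C)n3c2ncc(C(=O)O)c3=O)c1` stands lowest of the two numbers measured in a functional assay on the whole organism for inhibition, with Rattus norvegicus as the target (a higher number here means that more compound is needed for the effect, a lower number that less compound is needed), where compound 2 gives 0.2 umol/kg. Compound 1 `CCOC(=O)c1cnc2n(c1=O)C(C)CC/C2=N\Nc1cccc(C(=O)O)c1`, which also carries a carboxy group, gives 100 umol/kg in this assay, a gap well beyond the usual scatter. Compound 3 `CC1CC/C(=N\Nc2cccc(C(=O)O)c2)c2ncc(C(=O)O)c(=O)n21` has not yet been measured. Its difference from compound 2 is carboxy in place of ethoxy on an aromatic carbon. Since compound 1 with its carboxy group gives 100 umol/kg, a larger number is expected for compound 3. The step of a 150-fold higher number from compound 2 to compound 3 (2.18 log units; beyond the scatter) is expected to lie beyond the scatter. Compound 3 is estimated at 30 umol/kg, within a range from 3 umol/kg to 300 umol/kg.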

Compound 3, dose for 50% inhibition: 26.6 umol/kg
Estimate against measurement, compound 3: 1.1-fold (0.05 log units) above, and the stated range covers the measured number.
By their numbers in this assay, from the lowest: compound 2; then compound 3; then compound 1.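

In this assay, carboxy in place of ethoxy on an aromatic carbon gives a 130-fold higher number from compound 2 to compound 3 (2.12 log units; beyond the scatter), so this place on the ring separates the two groups sharply. With that carboxy group kept, hydrogen in place of ethyl on an oxygen next to a carbonyl group gives only a 3.8-fold lower number from compound 1 to compound 3 (0.58 log units; beyond the scatter), a modest step beside the large one. Nothing at hand gives a reason for either step.

Going by these compounds, whether a methoxy group, a longer alkoxy chain or an amine at the ethoxy place would keep a number as low as that of compound 2 stays open.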